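This account rests on a few compounds, and the source may have more. Where it says the series, first, only, none or still open, it means among the compounds named here.

Measured compounds:
- compound 1 `COc1cc(C(=O)c2sc(-c3cccs3)cc2N)cc(OC)c1OC` — in a functional assay on MOLT-4 cells (Homo sapiens) for antiproliferative activity (a higher number here means a weaker inhibitor, a lower number a stronger inhibitor), compound 1 gives 8.9 nM
- compound 2 `COc1cc(C(=O)c2sc(-c3ccc(C(F)(F)F)cc3)cc2N)cc(OC)c1OC` — in this assay compound 2 gives 250 nM
- compound 3 `COc1ccc(-c2cc(N)c(C(=O)c3cc(OC)c(OC)c(OC)c3)s2)cc1OC` — in this assay compound 3 gives 20 nM

Compound 2 stands highest of the three numbers in this assay: the step of a 28-fold higher number from compound 1 to compound 2 (1.45 log units; beyond the scatter) is large, and the step of a 13-fold lower number from compound 2 to compound 3 (1.10 log units; beyond the scatter) is also large, while a 2.2-fold higher number from compound 1 to compound 3 (0.35 log units; beyond the scatter) is only modest. The aryl group attached to the shared core therefore moves the number by a large amount, with 4-(trifluoromethyl)phenyl the weakest of the three variants tried.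

Compound 4 `COc1cc(C(=O)c2sc(-c3ccc(-c4ccccc4)cc3)cc2N)cc(OC)c1OC` keeps the shared core of compound 2 and changes only the aryl substituent: phenyl in place of trifluoromethyl on an aromatic carbon. Going by the values given here, no measured step replaces a trifluoromethyl with a phenyl, so the bearing of the three steps is indirect. They show only that the 4-(trifluoromethyl)phenyl variant sits well above the two others; a different substituent on the same phenyl may recover part of that gap, as compound 3 does. The expected step of a 2.8-fold lower number from compound 2 to compound 4 (0.44 log units; beyond the scatter) is therefore downward, of uncertain size. Compound 4 is estimated at 90 nM, within 20 nM to 500 nM.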

Compound 4, half-maximal inhibitory concentration: > 10000 nM
Compound 4: only a limit was reported; the forecaster's own chance of this, stated with the estimate: 5%; middle value at least 110-fold (2.04 log units) away from the limit.
By their numbers in this assay, from the lowest: compound 1; then compound 3; then compound 2. At a limit, above all of these: compound 4.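

In this assay, phenyl in place of trifluoromethyl on this aromatic carbon, para to a large group, gives an at least 40-fold higher number from compound 2 to compound 4 (1.60 log units; beyond the scatter), so a change confined to this one group can cost more than the change from thiophen-2-yl to 4-(trifluoromethyl)phenyl did. The reading for compound 4 is a limit of the assay, not a number: the limit of > 10000 nM in this assay, at which 1 of the 4 values shown sits. All the earlier steps ended on measured values, so this is the first change in the series shown to carry a compound to a limit.

From the compounds shown here alone, how far the number rises between trifluoromethyl and phenyl stays open, and so does the true value of compound 4. Also open, going by these compounds, is where a methyl, an amine or a carboxylic acid on the same carbon would fall, and whether any of them would come back towards compound 3.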